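The compounds below may be only part of what the source reports. "The series", "measured", "known", "first", "only" and "open" are said of these compounds alone.

Measured so far in a functional assay on the whole organism (strain Kunming) with Mus musculus as the target, with a stated time of 0.5 h; a lower number here means that less compound is needed, a higher number that more compound is needed for the effect
- compound 1 `COc1cc(OC)c(OC)cc1/C=C/COC(=O)/C=C/c1ccc(OC)c(OC)c1` gives 418 umol/kg
- compound 2 `COc1cc(OC)c(OC)cc1/C=C/COC(=O)/C=C/c1cccc(Br)c1` gives > 461 umol/kg as a limit of the assay, not a number
- compound 3 `COc1cc(OC)c(OC)cc1/C=C/COC(=O)/C=C/c1ccccc1Cl` gives 385 umol/kg

The two true numbers sit level, a 1.1-fold lower number from compound 1 to compound 3 (0.04 log units; within the scatter), which leaves compound 3 with no clear edge in the set. Compound 4 `COc1cc(OC)c(OC)cc1/C=C/COC(=O)/C=C/c1ccc(F)cc1` differs thus: 4-fluorophenyl in place of 2-chlorophenyl on a double-bonded chain carbon bound to a double-bonded chain carbon with 4-fluorophenyl in place of 2-chlorophenyl on a double-bonded chain carbon bound to a double-bonded chain carbon. Exchanges at this place have shown no step beyond the scatter, with an at least 1.1-fold higher number from compound 1 to compound 2 (0.04 log units; that floor lies within the scatter) and an at least 1.1-fold lower number from compound 2 to compound 3 (0.07 log units; that floor lies within the scatter) both only floors set on a limit. The expected step is a 1.0-fold higher number from compound 3 to compound 4 (0.02 log units; within the scatter) and so none beyond the scatter in this assay is expected. For compound 4 the estimated value is 400 umol/kg with an expected range of 230 umol/kg to 600 umol/kg overall.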

Compound 4, dose for half-maximal effect: 449 umol/kg
Estimate against measurement, compound 4: 1.1-fold (0.05 log units) below; the measured number falls inside the stated range.
By their numbers in this assay, from the lowest: compounds 3, 1 and 4 (each within the scatter of the next). At a limit, above all of these: compound 2.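

In this assay, 4-fluorophenyl in place of 2-chlorophenyl gives a 1.2-fold higher number from compound 3 to compound 4 (0.07 log units; within the scatter), and in place of 3,4-dimethoxyphenyl it gives a 1.1-fold higher number from compound 1 to compound 4 (0.03 log units; within the scatter). A fluorine-bearing phenyl thus joins the chlorine- and methoxy-bearing ones at this place without a step beyond the scatter. In place of 3-bromophenyl, 4-fluorophenyl gives an at least 1.0-fold lower number from compound 2 to compound 4 (0.01 log units; that floor lies within the scatter). That step is only a floor, because compound 2 stands at a limit and not at a number: the limit of > 461 umol/kg in this assay, at which 1 of the 4 values shown sits.

Still open, going by these compounds, is whether anything other than a substituted phenyl, such as an aminophenyl or a carboxylic acid on the ring, would give a step beyond the scatter at this place.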